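Chloro in place of hydrogen on the benzyl ring

The compounds below may be only part of what the source reports. "The series", "measured", "known", "first", "only" and "open" are said of these compounds alone.

Compound 1 `CC(C)Cc1ccc(C(C)C(=O)NCc2ccccc2)cc1` carries an unsubstituted benzyl amide on the shared core. In an assay on brain for inhibition of Fatty-acid amide hydrolase 1 (Rattus norvegicus), read by scintillation counting, with a stated time of 10 min (on this read-out lower numbers stand for stronger inhibition and higher numbers for weaker inhibition), compound 1 gives 21000 nM. For the measured compounds named here, only one other compound has been measured: compound 2 `COc1ccccc1CNC(=O)C(C)c1ccc(CC(C)C)cc1`, which differs from compound 1 by a methoxy in place of hydrogen on an aromatic carbon of the benzyl ring. In this assay compound 2 gives 18000 nM, so the change from compound 1 to compound 2 a 1.2-fold lower number from compound 1 to compound 2 (0.07 log units; within the scatter) stays within the scatter, and the two numbers cannot be told apart.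

Compound 3 `CC(C)Cc1ccc(C(C)C(=O)NCc2ccccc2Cl)cc1` is the next compound in line. It differs from compound 1 by chloro in place of hydrogen on an aromatic carbon, at the same position where compound 2 carries its methoxy. Going by the values given here, the single step that bears on this change, the methoxy step from compound 1 to compound 2 a 1.2-fold lower number from compound 1 to compound 2 (0.07 log units; within the scatter), did not move the number beyond the scatter. On that evidence, a chloro at the same place is expected to leave the number roughly where compound 1 stands, with no step beyond the scatter, so compound 3 is estimated at 18000 nM in this assay, within a range of 7000 nM to 50000 nM, an expected step of a 1.2-fold lower number from compound 1 to compound 3 (0.07 log units; within the scatter).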

Compound 3, half-maximal inhibitory concentration: 4100 nM
For compound 3 the middle estimate is 4.4-fold (0.64 log units) above the measured one; the measured number lies below the stated range.
By their numbers in this assay, from the lowest: compound 3; then compounds 2 and 1 (each within the scatter of the next).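

In this assay, this aromatic carbon turns out to respond to what is placed on it: chloro in place of hydrogen gives a 5.1-fold lower number from compound 1 to compound 3 (0.71 log units; beyond the scatter), a modest step, but the first one in this small set to pass beyond the scatter. The identity of the group matters as well, as chloro in place of methoxy on the same carbon gives a 4.4-fold lower number from compound 2 to compound 3 (0.64 log units; beyond the scatter), while methoxy in place of hydrogen gave only a 1.2-fold lower number from compound 1 to compound 2 (0.07 log units; within the scatter), so a substituent here does not by itself lower the number. Nothing available here explains why chloro and methoxy part ways on this carbon.

From the compounds shown here alone, it remains open whether this gain is particular to chloro or would also appear with fluoro, bromo or methyl on the same carbon, and how an amine or a carboxylic acid there would compare. It is equally open whether chloro would give a similar step on another carbon of this ring, since both substituted compounds shown carry their group at this one place.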